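Furan Replaces Imidazole: A Methoxymethyl Follow-Up

The source may report more compounds than this note shows. Statements on the series, on what has been measured and on what is new or still open speak of the compounds shown alone.

Measured compounds:
compound 1 `CC(C)(C)c1[nH]cnc1/C=c1\[nH]c(=O)/c(=C/c2cccc(Oc3ccc(F)cc3)c2)[nH]c1=O` — 4 nM
compound 2 `O=c1[nH]/c(=C\c2ccco2)c(=O)[nH]/c1=C\c1cccc(Oc2ccc(F)cc2)c1` — 155 nM

This account follows one unmeasured step. In a functional assay on NCI-H460 cells (Homo sapiens) for cytotoxicity, read by MTT assay, with a stated time of 72 h (a higher number here means a weaker inhibitor, a lower number a stronger inhibitor), compound 1 gives 4 nM. Compound 2 stands as the higher of the two numbers: in this assay compound 2 gives 155 nM, and its nearest neighbour is compound 1, reached by the change of a 39-fold higher number from compound 1 to compound 2 (1.59 log units; beyond the scatter). For the measured compounds named here, compound 3 `COCc1ccc(/C=c2\[nH]c(=O)/c(=C/c3cccc(Oc4ccc(F)cc4)c3)[nH]c2=O)o1` differs from compound 2 only in the furan ring: methoxymethyl in place of hydrogen on an aromatic carbon No measured step bears directly on this change; the single step in hand, from compound 1 to compound 2, swaps the whole five-membered ring rather than adding a substituent to it, so it offers no precedent for a methoxymethyl group placed on the furan. With no guide for direction, the expectation for compound 3 in this assay is a step of a 1.2-fold lower number from compound 2 to compound 3 (0.08 log units; within the scatter), which is not beyond the scatter. Compound 3 is therefore estimated at 130 nM, with a range from 40 nM to 450 nM.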

Compound 3, half-maximal inhibitory concentration: 14 nM
For compound 3 the middle estimate is 9.3-fold (0.97 log units) above the measured one; measured number below the stated range.
By their numbers in this assay, from the lowest: compound 1; then compound 3; then compound 2.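

In this assay, for the compounds shown here, the furan carbon next to the ring oxygen proves to be a position that responds to substitution: methoxymethyl in place of hydrogen there gives an 11-fold lower number from compound 2 to compound 3 (1.04 log units; beyond the scatter), a large step that the earlier compounds, with their exchange of one whole ring for another, could not foretell. The substituted furan also wins back much of the ground lost when furan-2-yl replaced 5-(tert-butyl)-1H-imidazol-4-yl, since the exchange of that imidazole group for 5-(methoxymethyl)furan-2-yl now leaves a 3.5-fold higher number from compound 1 to compound 3 (0.54 log units; beyond the scatter), a modest gap but still one beyond the scatter. Nothing at hand speaks to the cause of the gain at this position.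

The compounds shown leave open whether the gain belongs to the ether oxygen of the methoxymethyl group or to any chain on this carbon, a question that a methyl, an ethyl or a hydroxymethyl group in the same place would separate. Also open, as far as these compounds go, is whether a longer ether chain or an amine on this carbon would close the remaining gap to compound 1 in this assay or widen it.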